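Hydroxy for fluoro on the fused benzo ring

The source may report more compounds than this note shows. Statements on the series, on what has been measured and on what is new or still open speak of the compounds shown alone.

Among the measured compounds shown here, compound 2 `CC(=O)NCc1cccc(Cn2nc(NS(=O)(=O)c3ccc(Cl)s3)c3c(F)cccc32)c1` gives 5010 nM in an assay on isolated protein (blood) for antagonist activity at C-C chemokine receptor type 4 (Homo sapiens), read by flow cytometry, with a stated time of 30 min (a higher number here means weaker binding, a lower number tighter binding), and stands at the lower of the two numbers measured; compound 1 `CC(=O)NCc1cccc(Cn2nc(NS(=O)(=O)c3ccc(Cl)s3)c3c(Cl)cccc32)c1` gives 6310 nM, and the one measured step, a 1.3-fold lower number from compound 1 to compound 2 (0.10 log units; within the scatter), lies within the scatter. Compound 3 `CC(=O)NCc1cccc(Cn2nc(NS(=O)(=O)c3ccc(Cl)s3)c3c(O)cccc32)c1` carries hydroxy in place of fluoro on an aromatic carbon. For the measured compounds named here, no measured step bears on a hydroxy at this place; the halogen swap from compound 1 to compound 2 shows only that this position tolerates a small change without a shift beyond the scatter. The expected step is therefore a 1.0-fold lower number from compound 2 to compound 3 (0.00 log units; within the scatter), with no direction beyond the scatter assumed. Compound 3 is estimated at 5000 nM, range 1600 nM to 16000 nM.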

Compound 3, dissociation constant: 794 nM
Compound 3: the middle estimate sits 6.3-fold (0.80 log units) above what was measured; measured number outside the range, below it.
By their numbers in this assay, from the lowest: compound 3; then compounds 2 and 1 (each within the scatter of the next).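

In this assay, a 6.3-fold lower number from compound 2 to compound 3 (0.80 log units; beyond the scatter) and a 7.9-fold lower number from compound 1 to compound 3 (0.90 log units; beyond the scatter) are both beyond the scatter, whereas the swap between the two halogens stayed within it. This aromatic carbon therefore does respond to the group it carries, and hydroxy, which brings a hydrogen-bond donor that neither halogen has, gives the lowest number of the three. Nothing available here accounts for this difference.

From the compounds shown here alone, whether the lower number is specific to hydroxy remains open. A methoxy or an amine on this same carbon would test that.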